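Trimming the Methoxymethoxy Chain of a Chromone Dienone

The source may report more compounds than this note shows. Statements on the series, on what has been measured and on what is new or still open speak of the compounds shown alone.

Of the compounds shown here, two in this set have been tested in a functional assay on MCF7 cells (Homo sapiens) for cytotoxicity, read by colorimetric assay and MTT assay, with a stated time of 72 h; a lower number here means a stronger inhibitor, a higher number a weaker inhibitor. Compound 1, `COCOc1cc(O)c2c(=O)cc(C3(O)C=CC(=O)C=C3)oc2c1`, gives 5240 nM in this assay. Compound 2, `COC1(c2cc(=O)c3c(O)cccc3o2)C=CC(=O)C=C1`, gives 5460 nM in this assay. Compound 1 holds the lower of the two numbers, but its gap to compound 2 lies within the usual scatter, so the two are indistinguishable on these data.

Compound 3, `COc1cc(O)c2c(=O)cc(C3(O)C=CC(=O)C=C3)oc2c1`, has not yet been measured. It is reached from compound 1 by a single change: hydrogen in place of methoxy on a saturated chain carbon bound to an oxygen on an aromatic ring. Read one bond further out, the methoxymethoxy group becomes a methoxy group on the shared core, while the rest of compound 1 is kept.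

Going by the values given here, no measured pair in this set shows the effect of such a change, so nothing here says which way the number should move. Compound 3 is therefore expected to land near compound 1, with the step of a 1.0-fold lower number from compound 1 to compound 3 (0.02 log units; within the scatter) expected to stay within the scatter. The estimate for compound 3 is 5000 nM, within a range of 2000 nM to 13000 nM.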

Compound 3, half-maximal inhibitory concentration: 1700 nM
The estimate for compound 3 lay 2.9-fold (0.47 log units) above the measured number; the measured number lies below the stated range.
By their numbers in this assay, from the lowest: compound 3; then compounds 1 and 2 (each within the scatter of the next).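

Cutting the methoxymethoxy group back to a methoxy group on the shared core gives the first change in this set whose effect can be read, and in this assay it amounts to a 3.1-fold lower number from compound 1 to compound 3 (0.49 log units; beyond the scatter). The number at this position therefore responds to the chain: removing the methoxy from the saturated chain carbon bound to an oxygen on an aromatic ring does not cost activity here, and the shorter group gives the lower number. Nothing available on these compounds accounts for the shift, so the step stands as an observation only.

This is a single step on a single core, so it does not establish a trend with chain length. Going by these compounds, whether an ethoxy group, a longer chain or an amine at the same place would lower the number further or raise it again remains open.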